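Replacing a pyridine by a methoxyphenyl: expected lipophilicity change

The source may report more compounds than this note shows. Statements on the series, on what has been measured and on what is new or still open speak of the compounds shown alone.

Compound 1, `CC[C@@H](Nc1c(C#N)c(-c2ccc(-c3ncccc3C)cc2)nc2cnccc12)C(N)=O`, gives 2 in a physicochemical assay for lipophilicity, read by HPLC, at pH 7.5; on this read-out higher numbers stand for higher lipophilicity and lower numbers for lower lipophilicity.
Compound 2, `CCOc1ccccc1-c1ccc(-c2nc3cnccc3c(C[C@H](C)C(=O)O)c2C#N)cc1`, gives 2.2 in this assay.
Compound 3, `CC(Nc1c(C#N)c(-c2ccc(Br)cc2)nc2cnccc12)C(N)=O`, gives 2.1 in this assay.

Among these three numbers compound 1 has the lowest. Its nearest neighbour is compound 3, whose number lies within the scatter of it, and the number for compound 2 also lies within the scatter, so the three measured compounds cannot be told apart on this read-out. Going by the values given here, no single-point step between measured compounds is available, so nothing measured here shows how this kind of change moves the number.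

Compound 4, `CC[C@@H](Nc1c(C#N)c(-c2ccc(-c3cccc(OC)c3)cc2)nc2cnccc12)C(N)=O`, has not yet been measured. It differs from compound 1 in one place: 3-methoxyphenyl in place of 3-methylpyridin-2-yl on an aromatic carbon. The group that leaves and the group that enters each carry one hydrogen-bond acceptor and no donor, and neither carries a charge, while the entering ring is made of carbon only.

For compound 4 an upward step in this assay is expected, clearly beyond the scatter, with a number 0.70 log units higher from compound 1 to compound 4 (beyond the scatter) as the estimated size. Compound 4 is therefore expected to give about 2.7, within a range from 2.2 to 3.3.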

Compound 4, distribution coefficient: 2.7
Compound 4: the middle estimate sits on the measured number at the digits printed, within the range that was stated.
By their numbers in this assay, from the lowest: compounds 1, 3 and 2 (each within the scatter of the next); then compound 4.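

Going by these compounds alone, with 3-methoxyphenyl in place of 3-methylpyridin-2-yl on an aromatic carbon, para to a large group, this assay shows a number 0.70 log units higher from compound 1 to compound 4 (beyond the scatter) and so gives the first measured single-place step in this set. Compounds 1, 2 and 3 could not be told apart on this read-out, whereas this pair shows that the number can respond to a change at this one position while the rest of compound 1 stays the same. The step appears even though the leaving and entering groups both have the same counts of hydrogen-bond donors and acceptors and no net charge, but nothing measured here explains why the number moves.

This single swap changes several things at once: the ring nitrogen is lost, the methyl gives way to a methoxy, and the substituent's place on the ring differs, so the compounds shown cannot assign the step to any one of these. A plain phenyl ring, a 3-methylphenyl ring or a 3-methoxypyridine at this position would separate those changes, and a ring bearing a dimethylamino group would show how this read-out treats an amine here.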